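Thiosemicarbazone series: arylidene swap on the hydrazone carbon

The source may report more compounds than this note shows. Statements on the series, on what has been measured and on what is new or still open speak of the compounds shown alone.

Compound 1 `CC1=CC[C@H](C(C)(C)NC(=S)NN)CC1` is the open thiosemicarbazide of the series. In a functional assay on OVCAR-3 cells (Homo sapiens) for inhibition, read by sulforhodamine B assay, with a stated time of 48 h (a higher number here means a weaker inhibitor of growth, a lower number a stronger inhibitor of growth), compound 1 gives only a limit, > 100000 nM, and no number. Compound 2 `CC1=CC[C@H](C(C)(C)NC(=S)N/N=C/c2ccccc2O)CC1` carries a 2-hydroxyphenyl group on the hydrazone carbon. In this assay compound 2 gives 11800 nM. Among the measured compounds shown here, compound 2 therefore stands at the single numbered value so far. The remaining entry is the limit of compound 1, (the limit of > 100000 nM in this assay, at which 1 of the 2 values shown sits).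

Compound 3 `CC1=CC[C@H](C(C)(C)NC(=S)N/N=C/c2ccc(Cl)cc2)CC1` is not yet measured. It differs from compound 2 by 4-chlorophenyl in place of 2-hydroxyphenyl on a carbon with a double bond to nitrogen. For the measured compounds named here, no measured pair changes only this arylidene, so no step size can be read from the data. The hydrazone and the rest of compound 2 stay intact, so the expected step in this assay is one of no clear direction, within or only just beyond the scatter. Compound 3 is expected to give about 10000 nM, with a range of 3000 nM to 40000 nM. This corresponds to an estimated 1.2-fold lower number from compound 2 to compound 3 (0.07 log units; within the scatter).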

Compound 3, concentration for total growth inhibition: 26400 nM
For compound 3 the middle estimate is 2.6-fold (0.42 log units) below the measured one; low and high end bracket the measured number.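

The hydrazone carbon now has its first readable step: in this assay, 4-chlorophenyl in place of 2-hydroxyphenyl on a carbon with a double bond to nitrogen gives a 2.2-fold higher number from compound 2 to compound 3 (0.35 log units; beyond the scatter). Both groups keep a measurable value at this carbon, so growth inhibition here does not depend on retaining the 2-hydroxyphenyl group, although compound 2 has the lower number of the pair and the step is modest. No measured property bears on why the number moves in this direction, and the change itself alters the substituent, its place on the aromatic ring and the donor and acceptor counts together.

Among the compounds shown here, these contributions remain inseparable with only this pair, and an unsubstituted phenyl or a methoxyphenyl group on the same carbon would be needed to tell the loss of the hydroxyl from the entry of chlorine. For the compounds shown here, compound 1 is held only as a limit, > 100000 nM, so no step from it to either arylidene can be read.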